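Extending the biphenyl terminus: from hydroxymethyl to hydroxyphenyl

A few compounds are considered here, and "the series" means these few. Any claim that something is new, unique, unknown or untested is made for them only; others in the source may bear on it.

Two compounds share one core and differ at the far end of the biphenyl. Compound 1 `CC1(C)OC(=O)C2(C(=O)O1)[C@@H](c1ccc(-c3ccc(O)cc3)cc1)CC(=O)C[C@H]2c1ccccc1` carries a hydroxy there; in a functional assay on K562 cells (Homo sapiens) for antiproliferative activity, read by trypan blue exclusion, with a stated time of 48 h (a higher number here means a weaker inhibitor, a lower number a stronger inhibitor), compound 1 gives 9000 nM. Compound 2 `CC1(C)OC(=O)C2(C(=O)O1)[C@@H](c1ccc(-c3ccc(CO)cc3)cc1)CC(=O)C[C@H]2c1ccccc1` carries a hydroxymethyl instead, and in this assay compound 2 gives 38000 nM, the higher of the two numbers; the step of a 4.2-fold higher number from compound 1 to compound 2 (0.63 log units; beyond the scatter) sets the distance between them. Compound 3 `CC1(C)OC(=O)C2(C(=O)O1)[C@@H](c1ccc(-c3ccc(-c4ccc(O)cc4)cc3)cc1)CC(=O)C[C@H]2c1ccccc1` is the next member: 4-hydroxyphenyl in place of hydroxymethyl on an aromatic carbon. Within the data shown here, the only measured step that bears on this change is the one from compound 1 to compound 2, which showed that a hydroxy on the ring gave the lower number. Compound 3 restores a hydroxy, but on an added ring, so a moderate move back toward compound 1 is expected, with considerable uncertainty: the step is estimated as a 2.5-fold lower number from compound 2 to compound 3 (0.40 log units; beyond the scatter). In this assay compound 3 is expected to give about 15000 nM, within 4000 nM to 60000 nM.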

Compound 3, half-maximal inhibitory concentration: 8000 nM
The estimate for compound 3 lay 1.9-fold (0.27 log units) above the measured number, within the range that was stated.
By their numbers in this assay, from the lowest: compounds 3 and 1 (each within the scatter of the next); then compound 2.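

Putting 4-hydroxyphenyl in place of hydroxymethyl gives a 4.8-fold lower number from compound 2 to compound 3 (0.68 log units; beyond the scatter), which shows that this position in this assay can carry an added six-membered aromatic ring of carbon only. Compared with the hydroxy of compound 1, the same group gives a 1.1-fold lower number from compound 1 to compound 3 (0.05 log units; within the scatter), so the two cannot be told apart here even though 4-hydroxyphenyl has more heavy atoms. Nothing given here explains these numbers.

The compounds shown leave open whether the hydroxy on the added ring contributes at all, a question that an unsubstituted phenyl or a 4-methoxyphenyl would address. They also leave open how an amine or a carboxylic acid at this position would compare with the hydroxy of compound 1 and the hydroxymethyl of compound 2.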